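The compounds below may be only part of what the source reports. "The series", "measured", "known", "first", "only" and "open" are said of these compounds alone.

Measured compounds:
compound 1, `O=C(O)CC(NC(=O)c1cccc(Br)c1)c1ccccc1`, > 100000 nM
compound 2, `O=C(O)CC(NC(=O)c1ccc(Cl)cc1Cl)c1ccccc1`, 78200 nM
compound 3, `O=C(O)CC(NC(=O)c1cccc(Br)c1)c1ccccc1F`, > 100000 nM

In a functional assay on MDA-MB-436 cells (Homo sapiens) for antiproliferative activity, read by MTT assay, with a stated time of 24 h (on this read-out higher numbers stand for weaker inhibition and lower numbers for stronger inhibition), compound 1 gives > 100000 nM, which is a limit of the assay and not a number. Compound 3 gives > 100000 nM, again a limit. For the measured compounds named here, compound 2 gives 78200 nM, the only number among the three values shown. Compound 1 and compound 3 differ by fluoro in place of hydrogen on an aromatic carbon, and the step between them is a step that the two limits leave unreadable from compound 1 to compound 3; two of the three values sit at the limit of > 100000 nM in this assay, at which 2 of the 3 values shown sit, so the size of that step cannot be read. The difference between the core of compound 1 and the core of compound 2 is not broken down here.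

Compound 4, `O=C(O)CC(NC(=O)c1ccc(Cl)cc1Cl)c1ccccc1F`, has not yet been measured in this assay. It differs from compound 2 by fluoro in place of hydrogen on an aromatic carbon, the same change that leads from compound 1 to compound 3. He expects the step from compound 2 to compound 4 to be a 1.1-fold higher number from compound 2 to compound 4 (0.04 log units; within the scatter), a small one, resting on the unreadable step from compound 1 to compound 3 and on the weak value of compound 2 at 78200 nM. His estimate for compound 4 is 85000 nM, between 35000 nM and 200000 nM.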

Compound 4, half-maximal inhibitory concentration: > 100000 nM
Compound 4 was reported as a limit; the forecaster's own chance of this, stated with the estimate: 35%; middle value at least 1.1-fold (0.07 log units) away from the limit.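

In this assay compound 4 gives > 100000 nM, which is a limit of the assay and not a number. As far as these compounds go, on the core of compound 2, the change from phenyl to 2-fluorophenyl gives an at least 1.2-fold higher number from compound 2 to compound 4 (0.10 log units; that floor lies within the scatter), so it brings no gain in inhibition on this core, while the full size of the step stays unknown. The same change on the core of compound 1 cannot be read, so the two steps cannot be compared and nothing shows whether the change carries over from one core to the other with the same size, since the values crowd at one ceiling: the limit of > 100000 nM in this assay, at which 3 of the 4 values shown sit.

The compounds shown leave open whether a methyl ester in place of the carboxylic acid, or a longer chain carrying that acid, would give a number clear of the limit. They also leave open what a methoxy group or an amine in place of the chlorine atoms of compound 2 would do to the read-out.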